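Aryl change on the core nitrogen: compound 1 to compound 4

A few compounds are considered here, and "the series" means these few. Any claim that something is new, unique, unknown or untested is made for them only; others in the source may bear on it.

In an ADME assay on Huh-7 cells (Homo sapiens) for cytotoxicity (a lower number here means that less compound is tolerated, a higher number that more compound is tolerated), compound 1 `Cc1ccccc1-c1nn(-c2ccc(Cl)cc2)cc1CNCCN1CCN(C)CC1` gives 17000 nM, the lower of the two numbers recorded so far. Compound 2 `CN1CCN(CCNCc2cn(-c3ccc(F)cc3F)nc2-c2ccc(C(F)(F)F)cc2)CC1` gives 20000 nM in this assay, within the scatter of compound 1. Compound 3 `COc1ccc(-c2nn(-c3ccc(F)cc3F)cc2CNCCN2CCN(C)CC2)cc1` reaches only > 20000 nM in this assay, which is a limit of the assay and not a number. Within the data shown here, the single measured step, a number no lower from compound 2 to compound 3 (the limit leaves the size open), has a size that stays open because the limit of > 20000 nM in this assay, at which 1 of the 3 values shown sits, is all that is known of compound 3.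

Compound 4 `Cc1ccccc1-c1nn(-c2ccc(F)c(F)c2)cc1CNCCN1CCN(C)CC1` is not yet measured. It differs from compound 1 by 3,4-difluorophenyl in place of 4-chlorophenyl on an aromatic nitrogen. No measured step touches that part of the shared core: the only step recorded concerns methoxy and trifluoromethyl on an aromatic carbon, so nothing shown speaks directly to a change on the aromatic nitrogen. Among the measured compounds shown here, all three values sit close together, and the one known step is no lower. The step expected in this assay is therefore a 1.1-fold higher number from compound 1 to compound 4 (0.02 log units; within the scatter), none beyond the scatter in either direction. In this assay compound 4 is estimated at 18000 nM, between 8000 nM and 40000 nM, with a real chance that only the limit is reported.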

Compound 4, half-maximal cytotoxic concentration: > 20000 nM
Compound 4 ended at the assay's limit (the forecaster's own chance of this, stated with the estimate: 35%); middle value at least 1.1-fold (0.04 log units) away from the limit.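

Among these compounds, the aryl group on the aromatic nitrogen now has a measured step of its own, which the earlier compounds did not provide: in this assay, 3,4-difluorophenyl in place of 4-chlorophenyl gives an at least 1.1-fold higher number from compound 1 to compound 4 (0.07 log units; that floor lies within the scatter). From the compounds shown here alone, compound 4 gives > 20000 nM, which is a limit of the assay and not a number, so the change at this position shows no lower number, but its true size stays unknown and its floor lies within the scatter. This second limit means that the top of the measurable range now governs more of the series, which restricts what further comparisons can resolve: the limit of > 20000 nM in this assay, at which 2 of the 4 values shown sit.

Among the compounds shown here, it remains open whether any group on this aromatic nitrogen gives a number clearly lower or clearly higher than 4-chlorophenyl does, since the only aryl change compared here replaces one halogen-bearing phenyl group with another. A phenyl ring carrying an amine or a carboxylic acid at this position would test that, and it is also unknown whether the step would hold with a group other than 2-methylphenyl on the shared core.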